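The source may report more compounds than this note shows. Statements on the series, on what has been measured and on what is new or still open speak of the compounds shown alone.

Numbers from a functional assay on the whole organism (strain Wistar) for inhibition, with Rattus norvegicus as the target, read by paw edema, with a stated time of 24 h, at a dose of 100 mg/kg (a higher number here means more inhibition at the dose given (going by the name of the read-out), a lower number less inhibition), for the three measured compounds:

compound 1 `COc1cc2c(cc1OC)C(CC(=O)Nc1cccc(Cl)c1)CC2` gives 63.3%
compound 2 `COc1cc2c(cc1OC)C(CC(=O)Nc1cccc(C)c1)CC2` gives 41.7%
compound 3 `COc1cc2c(cc1OC)C(CC(=O)Nc1cccnc1)CC2` gives 36.7%

Compound 3 holds the lowest of the three numbers in this assay; compound 2 sits within the scatter of it, and only compound 1 lies beyond it, as the step of a number 26.6 percentage points lower from compound 1 to compound 3 (beyond the scatter) shows. Compound 4 `COc1cc2c(cc1OC)C(CC(=O)Nc1ccncc1)CC2` differs from compound 3 in one place: pyridin-4-yl in place of pyridin-3-yl on an amide-type nitrogen. Among the compounds with values here, no measured step exchanges one pyridyl for another. The steps at the same place, a number 26.6 percentage points lower from compound 1 to compound 3 (beyond the scatter) and a number 5 percentage points lower from compound 2 to compound 3 (within the scatter), exchange the whole aryl group, the first modest and beyond the scatter, the second within it. Neither matches the change at hand, so no step beyond the scatter is expected in this assay: a number 0.3 percentage points higher from compound 3 to compound 4 (within the scatter). Compound 4 is therefore estimated at 37%, expected between 22% and 52%.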

Compound 4, a percentage reported as inhibition, in the whole organism at one dose (the size of the read-out at that dose, not a potency): 46.7%
Estimate against measurement, compound 4: 9.7 percentage points below, within the range that was stated.
By their numbers in this assay, from the lowest: compounds 3, 2 and 4 (each within the scatter of the next); then compound 1.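

In this assay, within the data shown here, the first exchange of one pyridyl for another on this amide-type nitrogen gives a number 10 percentage points higher from compound 3 to compound 4 (within the scatter), so pyridin-4-yl and pyridin-3-yl are not separated here. Pyridin-4-yl is likewise not separated from 3-methylphenyl, with a number 5 percentage points higher from compound 2 to compound 4 (within the scatter), while the exchange from 3-chlorophenyl gives a number 16.6 percentage points lower from compound 1 to compound 4 (beyond the scatter), leaving compound 1 alone apart from the other three. Nothing available accounts for these results.

As far as these compounds go, whether bromo or trifluoromethyl in place of the chloro of compound 1 would keep that separation remains open.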